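Thiazolidinedione series: aryl swap on the pyrazoline ring

This account rests on a few compounds, and the source may have more. Where it says the series, first, only, none or still open, it means among the compounds named here.

Three compounds of the series have numbers in an assay on cells for inhibition of histone deacetylase 4 (Homo sapiens), read by fluorescence, with a stated time of 30 min; on this read-out lower numbers stand for stronger inhibition and higher numbers for weaker inhibition. Compound 1 `O=C1NC(=O)/C(=C\c2ccc(OCC(=O)N3N=C(c4ccccc4)CC3c3ccc(F)cc3)cc2)S1` gives 1700 nM. Going by the values given here, compound 2 `Cc1ccc(C2CC(c3ccccc3)=NN2C(=O)COc2ccc(/C=C3/SC(=O)NC3=O)cc2)cc1` gives 1200 nM, and the one measured step, a 1.4-fold lower number from compound 1 to compound 2 (0.15 log units; within the scatter), is the only single-point comparison in the set. Compound 3 `O=C1NC(=O)/C(=C\c2ccc(OCC(=O)N3N=C(c4ccc(F)cc4)CC3c3ccco3)cc2)S1` gives 880 nM, the lowest of the three numbers; its gap to compound 2 and its larger gap to compound 1 both fall within the scatter, so no order among the three can be claimed.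

Compound 4 `O=C1NC(=O)/C(=C\c2ccc(OCC(=O)N3N=C(c4ccc(F)cc4)CC3c3ccc(F)cc3F)cc2)S1` has not been measured. Relative to compound 3 the change is 2,4-difluorophenyl in place of furan-2-yl on a saturated ring carbon. Among the compounds with values here, no measured step isolates this exchange: compounds 1 and 2 carry six-membered carbon rings at the same saturated ring carbon, but they also differ from compound 3 in the other aryl group, so their values show only that such compounds sit in the same range as compound 3. The measured step from compound 1 to compound 2 bears on it only indirectly and was within the scatter. The expected step for compound 4 is therefore a 1.1-fold higher number from compound 3 to compound 4 (0.06 log units; within the scatter), with no direction asserted beyond the scatter. Compound 4 is estimated at 1000 nM, within 450 nM to 2400 nM.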

Compound 4, half-maximal inhibitory concentration: 1600 nM
Beside the measured number, compound 4's estimate is 1.6-fold (0.20 log units) below it, and the stated range covers the measured number.
By their numbers in this assay, from the lowest: compounds 3, 2, 4 and 1 (each within the scatter of the next).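

In this assay the exchange of furan-2-yl for 2,4-difluorophenyl on the saturated ring carbon can now be read in isolation, with the 4-fluorophenyl group held constant, and the step is a 1.8-fold higher number from compound 3 to compound 4 (0.26 log units; within the scatter) for this pair. This position therefore carries either a five-membered aromatic ring with 1 hetero atom and 1 hydrogen-bond acceptor (5 heavy atoms) or a six-membered aromatic ring of carbon only with 0 hydrogen-bond acceptors (8 heavy atoms), and the exchange gives no shift beyond the scatter, a reading that holds for this one pair and sets no trend. No independent data bear on the origin of this small step.

Going by these compounds, whether a group of a different kind on this saturated ring carbon, such as a carboxylic acid, an amine or a longer alkyl chain, would move the number beyond the scatter remains open. Also open is the contribution of the other aryl group, since no single-point step among these compounds isolates the exchange of phenyl and 4-fluorophenyl at that site.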